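Methoxy Added to the Anilino Group of Compound 3

The source may report more compounds than this note shows. Statements on the series, on what has been measured and on what is new or still open speak of the compounds shown alone.

Measured compounds in a functional assay on PC-3 cells (Homo sapiens) for cytotoxicity, read by MTT assay, with a stated time of 72 h; a lower number here means a stronger inhibitor, a higher number a weaker inhibitor:
compound 1 `O=S(=O)(c1ccccc1)c1nc2ccccc2nc1Nc1ccccc1`: 590 nM
compound 2 `COc1ccc(Nc2nc3ccccc3nc2S(=O)(=O)c2ccccc2)cc1`: 1510 nM
compound 3 `Cc1ccc(S(=O)(=O)c2nc3ccccc3nc2Nc2ccccc2)cc1`: 1060 nM

Compound 3 stands second highest of the three numbers, within the scatter of both compound 2 and compound 1. Compound 4 `COc1ccc(Nc2nc3ccccc3nc2S(=O)(=O)c2ccc(C)cc2)cc1` differs from compound 3 by methoxy in place of hydrogen on an aromatic carbon. The same change, made on compound 1 to give compound 2, bears directly on it: a 2.6-fold higher number from compound 1 to compound 2 (0.41 log units; beyond the scatter). For the measured compounds named here, the only other step, a 1.8-fold higher number from compound 1 to compound 3 (0.25 log units; within the scatter), is the methyl already present in compound 3. A similar modest rise in this assay is therefore expected for compound 4, giving an estimated 2.4-fold higher number from compound 3 to compound 4 (0.37 log units; beyond the scatter). Compound 4 is thus estimated at 2500 nM, with a range from 1200 nM to 5500 nM.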

Compound 4, half-maximal inhibitory concentration: > 50000 nM
Compound 4 gave a limit, no number; the forecaster's own chance of this, stated with the estimate: 3%; at least 20-fold (1.30 log units) between middle value and limit.
By their numbers in this assay, from the lowest: compounds 1, 3 and 2 (each within the scatter of the next, the first and the last beyond it). At a limit, above all of these: compound 4.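

In this assay compound 4 gives a limit and not a number, > 50000 nM. Methoxy on the anilino group thus has no fixed effect here, giving an at least 47-fold higher number from compound 3 to compound 4 (1.67 log units; beyond the scatter) when the methyl of compound 3 is present: the same change on two cores in this assay, a 2.6-fold higher number (0.41 log units; beyond the scatter) from compound 1 to compound 2 and an at least 47-fold higher number (1.67 log units; beyond the scatter) from compound 3 to compound 4, at least 18-fold (1.26 log units) apart, beyond the scatter of two such steps. Methyl likewise gives an at least 33-fold higher number from compound 2 to compound 4 (1.51 log units; beyond the scatter) once methoxy is present, so the large steps appear only with both groups together, in compound 4: the same change on two cores in this assay, a 1.8-fold higher number (0.25 log units; within the scatter) from compound 1 to compound 3 and an at least 33-fold higher number (1.51 log units; beyond the scatter) from compound 2 to compound 4, at least 18-fold (1.26 log units) apart, beyond the scatter of two such steps.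

From the compounds shown here alone, the true size of both steps stays unknown. Going by these compounds, whether an amine or a carboxylic acid in place of the methoxy would behave the same way on compound 3 also remains open.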